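Benzyl substituent swap on a shared xanthine-like core

The source may hold more compounds than are shown below. What is called first, only, known or untested is meant among the compounds shown, and "the series" means these compounds.

Three compounds share one core and differ only in the group on the saturated chain carbon bound to an aromatic nitrogen. Among the compounds with values here, compound 1 `CCCn1c(=O)c2nc(-c3cnn(Cc4cccc(Cl)c4)c3)[nH]c2n(CCC)c1=O` was tested in an assay on CHO cells for displacement of a labelled ligand from adenosine receptor A1 (Homo sapiens) (on this read-out lower numbers stand for stronger inhibition and higher numbers for weaker inhibition), and gives 31 nM, the only number in this set. Compound 2 `CCCn1c(=O)c2nc(-c3cnn(Cc4cccc(F)c4F)c3)[nH]c2n(CCC)c1=O` was prepared in the same series, but in this assay compound 2 gives "not determined" (no result reported), so it stands without a number and gives no anchor for comparison. Compound 3 `CCCn1c(=O)c2nc(-c3cnn(Cc4ccccc4OC)c3)[nH]c2n(CCC)c1=O` is not yet measured. Compound 3 differs from compound 2 by 2-methoxyphenyl in place of 2,3-difluorophenyl on a saturated chain carbon bound to an aromatic nitrogen. Within the data shown here, with no measured step available on either side of this change, the size and direction of its effect remain open; a shift on the order of the scatter, in either direction, would be unsurprising. Taking the single known value of compound 1 as the reference point for this core, compound 3 is expected to give roughly 60 nM, with a plausible range from 15 nM to 250 nM in this assay.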

Compound 3, inhibition constant: 59 nM
For compound 3 the middle estimate is 1.0-fold (0.01 log units) above the measured one; the range from low to high includes it.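

In this assay, the shared core now has a second number, and the exchange of 3-chlorophenyl for 2-methoxyphenyl on a saturated chain carbon bound to an aromatic nitrogen comes to a 1.9-fold higher number from compound 1 to compound 3 (0.28 log units; within the scatter), so the two groups cannot be told apart at this position on this read-out. The change from 2,3-difluorophenyl to 2-methoxyphenyl cannot be read, since compound 2 has no reported result and the new number has nothing to stand against on that side. Nothing measured here bears on why the two substituted phenyl groups cannot be told apart.

From the compounds shown here alone, what remains open is how this read-out responds at the same position to a group of a different kind, such as an amine or a carboxylic acid on the phenyl ring, or a longer chain in place of the single carbon that joins the ring to the aromatic nitrogen. Going by these compounds, it is also open whether 2,3-difluorophenyl would fall with the other two groups, as a single pair of numbers defines no trend for this position.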